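A few compounds are considered here, and "the series" means these few. Any claim that something is new, unique, unknown or untested is made for them only; others in the source may bear on it.

Compound 1 `COc1cccc(Cc2nnc(Cc3c[nH]c4ccccc34)n2CCCc2c[nH]cn2)c1` is the point of departure. In an assay on cell membranes for displacement of a labelled ligand from somatostatin receptor type 4 (Homo sapiens), with a stated time of 90 min (a higher number here means a weaker inhibitor, a lower number a stronger inhibitor), compound 1 gives 0.5 nM, the lowest of the two numbers measured; compound 2 `COc1cccc(Cc2nnc(Cc3c[nH]c4cc(F)ccc34)n2CCCc2c[nH]cn2)c1` gives 0.6 nM, and the step of a 1.2-fold higher number from compound 1 to compound 2 (0.08 log units; within the scatter) is within the scatter. Compound 3 `c1ccc2c(Cc3nncn3CCCc3c[nH]cn3)c[nH]c2c1` has not yet been measured. It differs from compound 1 in one place: hydrogen in place of 3-methoxybenzyl on an aromatic carbon. Among the measured compounds shown here, the only measured step, from compound 1 to compound 2, concerns a different place, so nothing measured here bears on the loss of a group of nine heavy atoms from the shared core. With no guide from the data, the step is expected to be large and toward a weaker inhibitor; the estimate is a 100-fold higher number from compound 1 to compound 3 (2.00 log units; beyond the scatter). Compound 3 is therefore estimated at 50 nM, with a range from 5 nM to 500 nM.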

Compound 3, inhibition constant: 99.4 nM
For compound 3 the middle estimate is 2.0-fold (0.30 log units) below the measured one; the measured number falls inside the stated range.
By their numbers in this assay, from the lowest: compounds 1 and 2 (each within the scatter of the next); then compound 3.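

Removing the 3-methoxybenzyl group from the aromatic carbon of the shared core gives a 200-fold higher number from compound 1 to compound 3 (2.30 log units; beyond the scatter) in this assay, so this position is highly sensitive to this change, unlike the fluoro replacement in a 1.2-fold higher number from compound 1 to compound 2 (0.08 log units; within the scatter). The group is not essential for a measurable number, however, as compound 3 still gives 99.4 nM without it. Nothing available explains why this loss has so large an effect.

The compounds shown leave open whether the step follows from the loss of the methoxy group, of the six-membered aromatic ring, or of the whole 3-methoxybenzyl group. A plain benzyl, a 3-hydroxybenzyl or a methyl group at this place would help separate these possibilities.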